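Swapping the Vinyl Iodide of Compound 1 for Chloride

The source may report more compounds than this note shows. Statements on the series, on what has been measured and on what is new or still open speak of the compounds shown alone.

Compound 1 `CCC[C@@H](O)C1=C(Br)/C(=C/I)OC1=O` has been measured in a functional assay on ZR-75-1 cells (Homo sapiens) for cytotoxicity (a lower number here means that less compound is needed, a higher number that more compound is needed for the effect), where compound 1 gives 0.3 ug/mL. Among the two numbers in hand this is the lowest; the nearest, compound 2 `CCC[C@@H](OC(C)=O)C1=C(Br)[C@](C)(OC)OC1=O`, gives 4 ug/mL. Compound 3 `CCC[C@@H](OC(C)=O)C1=C(Br)/C(=C/I)OC1=O` carries an acetyl in place of hydrogen on an oxygen on a saturated carbon. Compound 3 reaches only a limit of this assay, < 0.1 ug/mL. Among the compounds with values here, the one measured step in the set, an at least 3.0-fold lower number from compound 1 to compound 3 (0.47 log units; beyond the scatter), rests on (the limit of < 0.1 ug/mL in this assay, at which 1 of the 3 values shown sits).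

Compound 4 `CCC[C@@H](O)C1=C(Br)/C(=C/Cl)OC1=O` is not yet measured. It differs from compound 1 in one place: chloro in place of iodo on a double-bonded chain carbon bound to a double-bonded ring carbon. Within the data shown here, no measured step touches this position: the single known step alters the oxygen on the saturated carbon, not the halogen on the double-bonded chain carbon, so nothing measured here speaks directly to this exchange. Among the measured compounds shown here, with the rest of compound 1 kept as it is, no movement beyond the scatter is expected in this assay in either direction, though that rests on no precedent in this set. Compound 4 is therefore expected to give about 0.5 ug/mL, within 0.15 ug/mL to 2 ug/mL, which means an expected step of a 1.7-fold higher number from compound 1 to compound 4 (0.22 log units; within the scatter).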

Compound 4, concentration for half-maximal effect: 0.4 ug/mL
The estimate for compound 4 lay 1.3-fold (0.10 log units) above the measured number; low and high end bracket the measured number.
By their numbers in this assay, from the lowest: compounds 1 and 4 (each within the scatter of the next); then compound 2. At a limit, below all of these: compound 3.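

In this assay, within the data shown here, the exchange at this position gives a 1.3-fold higher number from compound 1 to compound 4 (0.12 log units; within the scatter), the first measured step at a double-bonded chain carbon bound to a double-bonded ring carbon. The earlier compounds shown here showed only what happens at the oxygen on the saturated carbon, whereas this pair shows that chloro and iodo cannot be told apart here in this assay, so iodo is not required at this position for a number in the range of compound 1. No measured property in the compounds shown accounts for this result.

Still open, on these data alone, is how groups other than these two halogens behave at the same position, among them fluoro, bromo, a nitrile or a plain hydrogen, and whether an acetyl on the oxygen on the saturated carbon would give the same kind of step with chloro in place as it gives with iodo, an at least 3.0-fold lower number from compound 1 to compound 3 (0.47 log units; beyond the scatter). That step with iodo has no exact size, since it rests on a limit of the assay and not on a number: the limit of < 0.1 ug/mL in this assay, at which 1 of the 4 values shown sits.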